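Ethoxycarbonyl in place of chloro: compound 3

The compounds below may be only part of what the source reports. "The series", "measured", "known", "first", "only" and "open" are said of these compounds alone.

Compound 1 `COc1cccc(Nc2nccc(-c3cccnc3)n2)c1` and compound 2 `Clc1cccc(Nc2nccc(-c3cccnc3)n2)c1` share one core and differ at a single aromatic carbon. In a functional assay for inhibition, with Homo sapiens as the target (on this read-out lower numbers stand for stronger inhibition and higher numbers for weaker inhibition), compound 1 gives 300 nM; compound 2 gives 1500 nM, the higher of the two numbers, separated by a 5.0-fold higher number from compound 1 to compound 2 (0.70 log units; beyond the scatter). Compound 3 `CCOC(=O)c1cccc(Nc2nccc(-c3cccnc3)n2)c1` carries the change (ethoxycarbonyl in place of chloro on an aromatic carbon). Among the measured compounds shown here, no measured step replaces chloro by ethoxycarbonyl; the only step at this carbon, a 5.0-fold higher number from compound 1 to compound 2 (0.70 log units; beyond the scatter), shows that a swap there can move the number modestly, in either direction. The step estimated here, a 1.5-fold lower number from compound 2 to compound 3 (0.18 log units; within the scatter), has no firmly supported direction. Compound 3 is therefore expected near 1000 nM, within 250 nM to 4000 nM.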

Compound 3, half-maximal inhibitory concentration: 10500 nM
For compound 3 the middle estimate is 11-fold (1.02 log units) below the measured one; the measured number lies above the stated range.
By their numbers in this assay, from the lowest: compound 1; then compound 2; then compound 3.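

Ethoxycarbonyl at this aromatic carbon gives a 7.0-fold higher number from compound 2 to compound 3 (0.85 log units; beyond the scatter) and a 35-fold higher number from compound 1 to compound 3 (1.54 log units; beyond the scatter) in this assay and so ranks last of the three groups, after methoxy and chloro. Among the compounds shown here, the step from methoxy is the first large step at this carbon, which shows that the position can move the number well beyond what the chloro swap showed. Nothing at hand accounts for this order.

As far as these compounds go, whether the weakening belongs to the whole ethoxycarbonyl group or to its ethyl part stays open; a carboxylic acid or a methyl ester at this carbon would bear on that. From the compounds shown here alone, how an amine there compares with methoxy also stays open.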